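From Cyclobutyl to a Hydroxylated Chain on the Amine

This account rests on a few compounds, and the source may have more. Where it says the series, first, only, none or still open, it means among the compounds named here.

Compound 1, `CC(C)c1nc(C(=O)NC2CCN(CC(C)(C)O)CC2)c2ccccn12`: 80%
Compound 2, `COCC(C)(C)CN1CCC(NC(=O)c2nc(C(C)C)n3ccccc23)CC1`: 74%
Compound 3, `CC(C)c1nc(C(=O)NC[C@@H]2[C@H]3CN(CC4CCC4)C[C@@H]23)c2ccccn12`: 50%

These values come from a functional assay on CHO cells for agonist activity at 5-hydroxytryptamine receptor 4 (Homo sapiens), read by a luciferase reporter and cAMP accumulation, with a stated time of 4 h; a higher number here means a larger maximal response, a lower number a smaller maximal response. Compound 3 stands lowest of the three, with compound 2 nearest and compound 1 furthest, both beyond the scatter. Compound 4, `CC(C)c1nc(C(=O)NC[C@@H]2[C@H]3CN(CC(C)(C)CO)C[C@@H]23)c2ccccn12`, differs from compound 3 by 1-(hydroxymethyl)-1-methylethyl in place of cyclobutyl on a saturated chain carbon bound to an amine nitrogen in a ring. For the measured compounds named here, the only measured step, a number 6 percentage points lower from compound 1 to compound 2 (within the scatter), swaps hydroxy for methoxymethyl on a different core and stays within the scatter, so it says little about trading a ring for a chain bearing a hydroxy group. Going by the values given here, no step on the core of compound 3 is available. A modest rise is therefore expected, with wide uncertainty: a number 10 percentage points higher from compound 3 to compound 4 (within the scatter). For compound 4 the estimate in this assay is 60%, with a range from 40% to 80%.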

Compound 4, largest response reached (Emax), in percent of the reference or control that the assay uses: 40%
Compound 4: middle estimate off by 20 percentage points, on the high side, and the stated range covers the measured number.
By their numbers in this assay, from the lowest: compounds 4 and 3 (each within the scatter of the next); then compounds 2 and 1 (each within the scatter of the next).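

On the core of compound 3, the change at this saturated chain carbon bound to an amine nitrogen in a ring gives a number 10 percentage points lower from compound 3 to compound 4 (within the scatter) in this assay and so shows no clear difference. Trading the cyclobutyl ring for an open chain bearing a hydroxy group therefore brings no gain in maximal response on this core. No measured evidence accounts for this result. Still open, on these data alone, is whether an amine or a carboxylic acid in place of that hydroxy group would shift the response beyond the scatter.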